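Naphthalenyl in Place of Benzodioxinyl: Expectation for Compound 3

This account rests on a few compounds, and the source may have more. Where it says the series, first, only, none or still open, it means among the compounds named here.

Going by the values given here, compound 2 `O=S(=O)(NCCCNCC1COc2ccccc2O1)c1cc(C(F)(F)F)cc(C(F)(F)F)c1` gives 3400 nM in a functional assay on PANC-1 cells (Homo sapiens) for inhibition, read by MTT assay, with a stated time of 72 h (on this read-out lower numbers stand for stronger inhibition of growth and higher numbers for weaker inhibition of growth), the lowest of the two numbers measured so far; its nearest neighbour, compound 1 `O=S(=O)(NCCCNCc1ccccc1Cl)c1cc(C(F)(F)F)cc(C(F)(F)F)c1`, gives 15000 nM, and the step of a 4.4-fold lower number from compound 1 to compound 2 (0.64 log units; beyond the scatter) lies beyond the scatter. Compound 3 `O=S(=O)(NCCCNCc1cccc2ccccc12)c1cc(C(F)(F)F)cc(C(F)(F)F)c1` has not been measured. It differs from compound 2 by naphthalen-1-yl in place of 2,3-dihydro-1,4-benzodioxin-2-yl on a saturated chain carbon bound to an amine nitrogen. Among the compounds with values here, only one measured step touches this position, a 4.4-fold lower number from compound 1 to compound 2 (0.64 log units; beyond the scatter), in which 2-chlorophenyl gave way to 2,3-dihydro-1,4-benzodioxin-2-yl. Within the data shown here, the entering naphthalen-1-yl, like the 2-chlorophenyl of compound 1, carries no hydrogen-bond acceptors, so part of that gain may be given back, though no measured pair shows this exact exchange. Compound 3 is therefore expected to show a modestly higher number, a step of a 1.8-fold higher number from compound 2 to compound 3 (0.25 log units; within the scatter), held with wide uncertainty. The estimate for compound 3 is 6000 nM, with a range from 2000 nM to 20000 nM.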

Compound 3, concentration for 50% growth inhibition: 2700 nM
The estimate for compound 3 lay 2.2-fold (0.35 log units) above the measured number, within the range that was stated.
By their numbers in this assay, from the lowest: compounds 3 and 2 (each within the scatter of the next); then compound 1.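

In this assay the exchange gives a 1.3-fold lower number from compound 2 to compound 3 (0.10 log units; within the scatter), so at this position naphthalen-1-yl cannot be told apart from 2,3-dihydro-1,4-benzodioxin-2-yl, although the entering group has 0 hydrogen-bond acceptors and the leaving group has 2. The all-carbon naphthalen-1-yl also gives a 5.6-fold lower number from compound 1 to compound 3 (0.74 log units; beyond the scatter), which shows that a group without hydrogen-bond acceptors can stand on this saturated chain carbon and still differ from 2-chlorophenyl beyond the scatter. No measurement at hand explains why these groups compare as they do.

The compounds shown leave open whether the difference from compound 1 follows the chlorine of 2-chlorophenyl or the second ring of naphthalen-1-yl. An unsubstituted phenyl or a naphthalen-2-yl at this position would help to separate the two.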